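The source may hold more compounds than are shown below. What is called first, only, known or untested is meant among the compounds shown, and "the series" means these compounds.

The measured compounds and their values in a functional assay on CHO cells for agonist activity at Free fatty acid receptor 2 (Homo sapiens), read by cAMP accumulation; on this read-out lower numbers stand for stronger inhibition and higher numbers for weaker inhibition:

compound 1, `CC(C)[C@H](C(=O)Nc1ncc(C(F)(F)F)s1)c1ccc(Cl)cc1`, 1500 nM
compound 2, `CC(C)(C)[C@H](C(=O)Nc1ncc(F)s1)c1ccc(Cl)cc1`, 700 nM
compound 3, `CC(C)(C)[C@H](C(=O)Nc1ncc(Br)s1)c1ccc(Cl)cc1`, 700 nM

Compound 3 stands level with compound 2 at the digits shown, and the two of them together hold the lowest numbers of the three in this assay ; compound 1 is the furthest away, and its gap from compound 3 lies beyond the scatter. Within the data shown here, only one single-change step has been measured: no change at the digits printed from compound 2 to compound 3 (within the scatter), an exchange of one halogen for another on the five-membered ring that left the read-out unchanged.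

Compound 4, `CC(C)(C)[C@H](C(=O)Nc1ncc(C(F)(F)F)s1)c1ccc(Cl)cc1`, takes the next step from compound 3: trifluoromethyl in place of bromo on an aromatic carbon. Among the measured compounds shown here, no measured pair shows this exact exchange. Compound 1 carries the same trifluoromethyl group, but it also differs from compound 4 in the alkyl branch, so its value cannot be set directly against compound 3. For the measured compounds named here, the one step that is known on this ring carbon is small, and a similarly small step is expected here, with a slight lean toward the higher number seen for compound 1. The expected step for compound 4 is a 1.2-fold higher number from compound 3 to compound 4 (0.08 log units; within the scatter). The estimate for compound 4 in this assay is 850 nM, with a range from 350 nM to 2000 nM.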

Compound 4, half-maximal inhibitory concentration: 1500 nM
Compound 4: middle estimate off by 1.8-fold (0.25 log units), on the low side, and the stated range covers the measured number.
By their numbers in this assay, from the lowest: compounds 2 and 3 (each within the scatter of the next); then compounds 1 and 4 (each within the scatter of the next).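

Among these compounds, on the aromatic carbon next to the ring sulfur, trifluoromethyl is the first group seen to move the read-out in this assay: in place of bromo it gives a 2.1-fold higher number from compound 3 to compound 4 (0.33 log units; beyond the scatter), and in place of fluoro it gives a 2.1-fold higher number from compound 2 to compound 4 (0.33 log units; beyond the scatter), whereas exchanging one halogen for the other had left the number unchanged. The alkyl branch makes no difference while trifluoromethyl sits on this carbon, with methyl in place of hydrogen on the saturated chain carbon giving no change at the digits printed from compound 1 to compound 4 (within the scatter), so the higher number of compound 1 is matched by compound 4 and cannot be tied to the missing methyl. Nothing in hand explains why trifluoromethyl parts from the two halogens on this carbon.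

The compounds shown leave open whether the same methyl exchange on the chain carbon would also leave the number unchanged with fluoro or bromo on the ring carbon. They also leave open whether a nitrile, a methyl or an amine at this place would stay level with the halogens or go with trifluoromethyl.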